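A few compounds are considered here, and "the series" means these few. Any claim that something is new, unique, unknown or untested is made for them only; others in the source may bear on it.

Three ureas built on one shared core have been tested for their ability to slow the growth of bladder cancer cells. In a functional assay on T-24 cells (Homo sapiens) for antiproliferative activity, read by MTT assay, with a stated time of 48 h (on this read-out lower numbers stand for stronger inhibition and higher numbers for weaker inhibition), compound 1 `O=C(Nc1ccc(Cl)cc1)Nc1cccc(CNc2nccnc2Cl)c1` gives 5470 nM. Compound 2 `O=C(Nc1cccc(CNc2nccnc2Cl)c1)Nc1ccc(Cl)cc1Cl` gives 5740 nM in this assay. The change between them is chloro in place of hydrogen on an aromatic carbon, and it made a 1.0-fold higher number from compound 1 to compound 2 (0.02 log units; within the scatter). Compound 3 `Cc1ccc(NC(=O)Nc2cccc(CNc3nccnc3Cl)c2)cc1` differs from compound 1 by methyl in place of chloro on an aromatic carbon; in this assay compound 3 gives 9820 nM, a step of a 1.8-fold higher number from compound 1 to compound 3 (0.25 log units; within the scatter).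

Compound 4 `Cc1ccc(NC(=O)Nc2cccc(CNc3nccnc3Cl)c2)cc1Cl` has not yet been measured. It differs from compound 3 by chloro in place of hydrogen on an aromatic carbon. For the measured compounds named here, this is the same kind of change as the one from compound 1 to compound 2, though not the same: there the entering chloro sat ortho to a large group and meta to a chloro group, whereas here it sits ortho to a methyl group and meta to a large group. The step from compound 3 to compound 4 in this assay is expected to be a 1.0-fold lower number from compound 3 to compound 4 (0.01 log units; within the scatter), because the earlier step of this kind measured a 1.0-fold higher number from compound 1 to compound 2 (0.02 log units; within the scatter). Compound 4 is therefore estimated at 9500 nM, expected to fall between 4500 nM and 20000 nM.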

Compound 4, half-maximal inhibitory concentration: 7390 nM
For compound 4 the middle estimate is 1.3-fold (0.11 log units) above the measured one, and the stated range covers the measured number.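

In this assay, chloro in place of hydrogen on an aromatic carbon gives a 1.3-fold lower number from compound 3 to compound 4 (0.12 log units; within the scatter), and the two measured cases of this change do not differ: the same change on two cores in this assay, a 1.0-fold higher number (0.02 log units; within the scatter) from compound 1 to compound 2 and a 1.3-fold lower number (0.12 log units; within the scatter) from compound 3 to compound 4, 1.4-fold (0.14 log units) apart, within the scatter of two such steps. The other two new steps are also small, with a 1.3-fold higher number from compound 2 to compound 4 (0.11 log units; within the scatter) and a 1.4-fold higher number from compound 1 to compound 4 (0.13 log units; within the scatter), so the 3-chloro-4-methylphenyl group stands within the scatter of both other groups it was compared with. This shows that, across these two cases, adding the chloro leaves no readable mark on the number, but it does not show a transferable effect, since neither step can be told apart from repeat-measurement noise and two cases make a very small sample.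

The compounds shown leave open whether a different group on this aromatic ring, such as an amine, a carboxylic acid or a longer chain, would move the number beyond the scatter. They also leave open whether the chloro step would stay this small on a core other than these two or in other cells.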